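A few compounds are considered here, and "the series" means these few. Any claim that something is new, unique, unknown or untested is made for them only; others in the source may bear on it.

Working notes on the series in a functional assay on MCF7 cells (Homo sapiens) for antiproliferative activity; on this read-out higher numbers stand for weaker inhibition and lower numbers for stronger inhibition.

Compound 1 `CC(=O)Oc1ccc2cc(-n3cc(-c4ccc(N(C)C)cc4)nn3)c(=O)oc2c1C` is one of two members of the set that return only a limit: in this assay compound 1 gives > 100000 nM, a limit of the assay rather than a number. Compound 3 `CC(=O)Oc1ccc2cc(-n3cc(/C=C/c4ccccc4)nn3)c(=O)oc2c1C` carries the change 2-phenylethenyl in place of 4-(dimethylamino)phenyl on an aromatic carbon and in this assay compound 3 gives 28500 nM. The step is an at least 3.5-fold lower number from compound 1 to compound 3 (0.54 log units; beyond the scatter); the limit on compound 1 means only its lower bound is known, which is noted in the limit of > 100000 nM in this assay, at which 2 of the 3 values shown sit.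

Compound 2 `CO[C@@H]1[C@@H](O)[C@@H](O)[C@H](Oc2ccc3c(c2C)OC(=O)C(n2cc(-c4ccc(N(C)C)cc4)nn2)C3)OC1(C)C` stands on a core that differs from that of compound 1 in more than one place, and the difference between the two cores is not broken down here. In this assay compound 2 gives > 100000 nM, again a limit and not a number.

Compound 4 `CO[C@@H]1[C@@H](O)[C@@H](O)[C@H](Oc2ccc3c(c2C)OC(=O)C(n2cc(/C=C/c4ccccc4)nn2)C3)OC1(C)C` is not yet measured. Its relation to compound 2 is 2-phenylethenyl in place of 4-(dimethylamino)phenyl on an aromatic carbon, the same change as from compound 1 to compound 3, with the place described in identical words. On that basis the step from compound 2 to compound 4 is expected to be of the order of an at least 2.0-fold lower number from compound 2 to compound 4 (0.30 log units; that floor lies within the scatter), resting on the measured step of an at least 3.5-fold lower number from compound 1 to compound 3 (0.54 log units; beyond the scatter). The starting point is the limit that compound 2 gives, > 100000 nM. For compound 4 the estimate is 50000 nM, expected to lie between 12000 nM and 200000 nM, with a real chance that the assay again reports only a limit.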

Compound 4, half-maximal inhibitory concentration: 14600 nM
Compound 4: the middle estimate sits 3.4-fold (0.53 log units) above what was measured; the measured number falls inside the stated range.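

In this assay, 2-phenylethenyl in place of 4-(dimethylamino)phenyl gives an at least 6.8-fold lower number from compound 2 to compound 4 (0.83 log units; beyond the scatter), so the direction of the step is the same on both cores shown, though two pairs are too few to make this a general rule: the same change on two cores in this assay, an at least 3.5-fold lower number (0.54 log units; beyond the scatter) from compound 1 to compound 3 and an at least 6.8-fold lower number (0.83 log units; beyond the scatter) from compound 2 to compound 4; the limit leaves it open whether they differ

This does not show that the size of the step carries over, since each step has a lower bound and no exact size, and neither core can be said to respond more strongly to the change. Both steps start from a limit of the assay and not from a number: the limit of > 100000 nM in this assay, at which 2 of the 4 values shown sit.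

The groups shown on the five-membered aromatic ring with 3 nitrogen are only 4-(dimethylamino)phenyl and 2-phenylethenyl, and these differ in more than one feature, so it remains open whether the step follows from losing the dimethylamino group or from gaining the double bond. A plain phenyl and a saturated 2-phenylethyl chain at the same place on both cores would separate these two features and could show whether the direction of the step holds beyond these two pairs.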